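Swapping One Ring on a Short-Lived Compound

This account rests on a few compounds, and the source may have more. Where it says the series, first, only, none or still open, it means among the compounds named here.

Compound 1 `CCn1ncc2c(F)cc(-c3ccc(C(CC)(CC)c4nncn4C)c(=O)[nH]3)cc21`: > 3 h
Compound 2 `Cc1nc(C(c2ccc(-c3ccc4cccc(F)c4c3)[nH]c2=O)C(C)C)[nH]c1C`: 0.0733 h

In an ADME assay on microsomes from liver (Rattus norvegicus) for metabolic stability (a higher number here means that the compound lasts longer, a lower number that the compound disappears faster), compound 1 gives > 3 h, which is a limit of the assay and not a number. Going by the values given here, compound 2 gives 0.0733 h, the only true number so far and the lower of the two results. Compound 3 `CC(C)C(c1noc(=O)[nH]1)c1ccc(-c2ccc3cccc(F)c3c2)[nH]c1=O` differs from compound 2 in one place: a group of 6 heavy atoms (2 carbon, 2 nitrogen, 2 oxygen; one five-membered aromatic ring with 3 hetero atoms) in place of a group of 7 heavy atoms (5 carbon, 2 nitrogen; one five-membered aromatic ring with 2 hetero atoms), on a saturated chain carbon bound to an aromatic carbon and a saturated chain carbon. Among the compounds with values here, no measured pair shows what this swap does, so the expectation is loose. Compound 2 starts low at 0.0733 h, so a moderate rise beyond the scatter seems more likely than a fall. The expected change is a 3.0-fold higher number from compound 2 to compound 3 (0.48 log units; beyond the scatter). For compound 3 the estimated half-life is 0.22 h, with an expected range of 0.08 h to 0.7 h.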

Compound 3, half-life: > 3 h
Compound 3 was reported as a limit (the forecaster's own chance of this, stated with the estimate: 3%); middle value at least 13-fold (1.13 log units) away from the limit.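

In this assay, replacing the 4,5-dimethyl-1H-imidazol-2-yl group with the five-membered aromatic ring with 3 hetero atoms gives an at least 40-fold higher number from compound 2 to compound 3 (1.61 log units; beyond the scatter). Compounds 2 and 3 differ in one place, so this large change can be tied to the group on that saturated chain carbon, which compound 1 alone could not show. The result for compound 3 is a limit of the assay and not a number: the limit of > 3 h in this assay, at which 2 of the 3 values shown sit.

Still open, as far as these compounds go, is whether a carboxylic acid on that same carbon would give a similar result. Also open, from the compounds shown here alone, is whether an imidazole without the methyl groups would stay as short-lived as compound 2.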